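Phthalimide thiocarbamates: cytotoxicity, aryl carbonyl swap

A few compounds are considered here, and "the series" means these few. Any claim that something is new, unique, unknown or untested is made for them only; others in the source may bear on it.

Three members of the series have been measured in an ADME assay on MT4 cells (Homo sapiens) for cytotoxicity, read by MTT assay; a higher number here means that more compound is tolerated, a lower number that less compound is tolerated. Compound 1 `O=C1c2ccccc2C(=O)N1CCOC(=S)N(C(=O)c1ccc(Br)cc1)c1ccc(Br)cc1` gives 73000 nM. Compound 2 `Cc1ccc(C(=O)N(C(=S)OCCN2C(=O)c3ccccc3C2=O)c2ccc(C)cc2)cc1` gives 83000 nM. Compound 3 `O=C1c2ccccc2C(=O)N1CCOC(=S)N(C(=O)c1cccc(F)c1F)c1ccc(Cl)cc1` gives 58000 nM; its number is the smallest of the three, but both compound 1 and compound 2 lie within the usual scatter of it, so the three compounds cannot be told apart on this assay.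

Compound 4 `COc1cccc(OC)c1C(=O)N(C(=S)OCCN1C(=O)c2ccccc2C1=O)c1ccc(Cl)cc1` has not been measured. It differs from compound 3 at one position only: 2,6-dimethoxyphenyl in place of 2,3-difluorophenyl on a carbonyl carbon. The shared core and the chlorophenyl on the amide-type nitrogen are unchanged. For the measured compounds named here, no step between measured compounds isolates this kind of change, so no direction can be taken from the data. What the data do show is that three different aryl carbonyl groups, together with three different aryl groups on the nitrogen, have left this assay unmoved beyond the scatter.

On that basis compound 4 is expected to sit with the others: the estimate is 65000 nM, within 30000 nM to 140000 nM. The expected step of a 1.1-fold higher number from compound 3 to compound 4 (0.05 log units; within the scatter) is none beyond the scatter, and the estimate for compound 4 rests on compound 3 with 58000 nM as the nearest point.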

Compound 4, half-maximal cytotoxic concentration: 69000 nM
Estimate against measurement, compound 4: 1.1-fold (0.03 log units) below, within the range that was stated.
By their numbers in this assay, from the lowest: compounds 3, 4, 1 and 2 (each within the scatter of the next).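

For the compounds shown here, this is the first step that changes one place only: in this assay, 2,6-dimethoxyphenyl in place of 2,3-difluorophenyl on a carbonyl carbon gives a 1.2-fold higher number from compound 3 to compound 4 (0.08 log units; within the scatter), so the two compounds cannot be told apart. Compounds 1, 2 and 3 differ in both aryl groups at once, whereas here the shared core and the chlorophenyl on the amide-type nitrogen stay fixed, which ties the result to the carbonyl position alone. At this position, therefore, an exchange of two fluorine atoms for two methoxy groups, with the hydrogen-bond acceptor count going from 0 to 2, leaves the number within the scatter, and nothing available accounts for this result.

As far as these compounds go, both aryl groups in this step are six-membered aromatic rings of carbon only, so it remains open whether a carboxylic acid, an amine or a saturated cyclohexyl group at the same carbonyl carbon would also stay within the scatter. The aryl group on the amide-type nitrogen has no single-place step among the compounds shown, so its own contribution remains unread.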